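Pyridinyl Amide Replaces Dichlorophenyl on a Shared Core

This account rests on a few compounds, and the source may have more. Where it says the series, first, only, none or still open, it means among the compounds named here.

Compound 3 `O=C(Nc1ccc(Cl)c(-c2nnc3c(Cl)cccn23)c1)c1ccc(Cl)cc1Cl` gives 61300 nM in a functional assay on A549 cells (Homo sapiens) for antiproliferative activity, read by MTT assay, with a stated time of 72 h (on this read-out higher numbers stand for weaker inhibition and lower numbers for stronger inhibition), the higher of the two numbers shown, though compound 2 `O=C(Nc1ccc(Cl)c(-c2nnc3c(Cl)cccn23)c1)c1ccon1` sits within the scatter of it at 42700 nM. Compound 1 `O=C(Nc1ccc(Cl)c(-c2nnc3c(Cl)cccn23)c1)c1ccccc1Cl` gives > 100000 nM, which is a limit of the assay and not a number, namely (the limit of > 100000 nM in this assay, at which 1 of the 3 values shown sits). The change to compound 4 `O=C(Nc1ccc(Cl)c(-c2nnc3c(Cl)cccn23)c1)c1cccnc1` is pyridin-3-yl in place of 2,4-dichlorophenyl on a carbonyl carbon. Within the data shown here, two measured steps bear on it: an at least 2.3-fold lower number from compound 1 to compound 2 (0.36 log units; beyond the scatter) and a 1.4-fold higher number from compound 2 to compound 3 (0.16 log units; within the scatter), so exchanging a chlorinated phenyl for a heteroaryl on the carbonyl carbon has given at most a modest lower number. Compound 4 is therefore expected to show a 1.5-fold lower number from compound 3 to compound 4 (0.19 log units; within the scatter), a small downward step or none beyond the scatter. Compound 4 is estimated at 40000 nM, with a range from 15000 nM to 100000 nM.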

Compound 4, half-maximal inhibitory concentration: > 100000 nM
Compound 4: no number, only a limit; the forecaster's own chance of this, stated with the estimate: 20%; middle value at least 2.5-fold (0.39 log units) away from the limit.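

Pyridin-3-yl in place of 1,2-oxazol-3-yl on the carbonyl carbon gives an at least 2.3-fold higher number from compound 2 to compound 4 (0.36 log units; beyond the scatter), so the two heteroaryl groups do not behave alike at this position in this assay. Against the dichlorinated amide, the change gives an at least 1.6-fold higher number from compound 3 to compound 4 (0.21 log units; that floor lies within the scatter), so compound 4 is not shown to differ from compound 3. Compound 4 stands at a limit of the assay and not at a number, and its step with compound 1 cannot be read: the limit of > 100000 nM in this assay, at which 2 of the 4 values shown sit.

On these data alone, whether pyridin-4-yl would behave like pyridin-3-yl on this carbonyl carbon remains open. So does whether a phenyl ring carrying an amine or a carboxylic acid would give a number well below those of the shared core.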